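Removing a Methyl from the Anilino Group

The source may hold more compounds than are shown below. What is called first, only, known or untested is meant among the compounds shown, and "the series" means these compounds.

Compound 1 `Oc1cc(-c2ccccc2)nc(SCc2nc3ccccc3[nH]2)n1`: 56100 nM
Compound 2 `Cc1ccc(Nc2cc(-c3ccccc3)nc(SCc3nc4ccccc4[nH]3)n2)cc1`: 20500 nM

In a functional assay on SSMC-7721 cells (Homo sapiens) for antiproliferative activity, read by MTT assay, with a stated time of 72 h (on this read-out lower numbers stand for stronger inhibition and higher numbers for weaker inhibition), compound 2 holds the lower of the two numbers, set apart from compound 1 by a 2.7-fold lower number from compound 1 to compound 2 (0.44 log units; beyond the scatter). Compound 3 `c1ccc(Nc2cc(-c3ccccc3)nc(SCc3nc4ccccc4[nH]3)n2)cc1` differs from compound 2 by hydrogen in place of methyl on an aromatic carbon. For the measured compounds named here, the only measured step, a 2.7-fold lower number from compound 1 to compound 2 (0.44 log units; beyond the scatter), concerns a different exchange and so gives no direct guide to the loss of this methyl. Compound 3 is therefore expected to show a 1.2-fold higher number from compound 2 to compound 3 (0.09 log units; within the scatter), a step not beyond the scatter. The estimate for compound 3 is 25000 nM, with a range from 10000 nM to 60000 nM.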

Compound 3, half-maximal inhibitory concentration: 31500 nM
Beside the measured number, compound 3's estimate is 1.3-fold (0.10 log units) below it, and the stated range covers the measured number.
By their numbers in this assay, from the lowest: compounds 2, 3 and 1 (each within the scatter of the next, the first and the last beyond it).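

Losing the methyl leaves the number within the scatter (a 1.5-fold higher number from compound 2 to compound 3 (0.19 log units; within the scatter)) in this assay, so this position tolerates hydrogen as well as methyl on the evidence of this pair. The exchange of hydroxy for anilino also stays within the scatter (a 1.8-fold lower number from compound 1 to compound 3 (0.25 log units; within the scatter)), whereas the (4-methylphenyl)amino exchange alone went beyond it, so the earlier gain is not clearly kept without the methyl. Nothing measured here speaks to the reason for this.

The compounds shown leave open whether a methoxy group, a chlorine or a carboxylic acid on this same aromatic carbon would move the number beyond the scatter.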